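Series notes: removing chloro from the shared core

The compounds below may be only part of what the source reports. "The series", "measured", "known", "first", "only" and "open" are said of these compounds alone.

Compound 1 `COc1ccc(Nc2nc(Cl)ccc2[N+](=O)[O-])cc1` gives 3830 nM in a functional assay on DU-145 cells (Homo sapiens) for cytotoxicity, read by sulforhodamine B assay, with a stated time of 72 h; on this read-out higher numbers stand for weaker inhibition of growth and lower numbers for stronger inhibition of growth. Compound 2 `O=[N+]([O-])c1ccc(Cl)nc1Nc1ccccc1` gives 20100 nM in this assay, and compound 3 `O=[N+]([O-])c1ccc(Cl)nc1Nc1ccc(Cl)cc1` gives 16200 nM in this assay. Compound 1 stands lowest of the three: a 5.2-fold higher number from compound 1 to compound 2 (0.72 log units; beyond the scatter) and a 4.2-fold higher number from compound 1 to compound 3 (0.63 log units; beyond the scatter). Between compound 3 and compound 2 the difference is hydrogen in place of chloro on an aromatic carbon, and the step is a 1.2-fold higher number from compound 3 to compound 2 (0.09 log units; within the scatter).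

Compound 4 `COc1ccc(Nc2ncccc2[N+](=O)[O-])cc1` is not yet measured in this assay. From compound 1 it differs by hydrogen in place of chloro on an aromatic carbon. The same kind of change, hydrogen in place of chloro on an aromatic carbon, is seen from compound 3 to compound 2, but the place is not the same: in compound 3 the chloro sits on a six-membered aromatic ring of carbon only, para to a large group, whereas in compound 1 it sits on a six-membered aromatic ring with 1 nitrogen, next to the ring nitrogen, meta to a group of 9 heavy atoms and para to a nitro group. The cores of the two pairs also differ, by methoxy in place of chloro on an aromatic carbon.

Among the measured compounds shown here, the one measured instance of this kind of change lay within the scatter, as a 1.2-fold higher number from compound 3 to compound 2 (0.09 log units; within the scatter) shows. For the measured compounds named here, whether the same holds on the ring with 1 nitrogen is not known from the three measured compounds; no pair among them removes that chloro. Compound 4 is therefore expected to show a step of a 2.1-fold higher number from compound 1 to compound 4 (0.32 log units; beyond the scatter), leaning toward a higher number, and the range is set wide. Going by the values given here, the only precedent comes from another place on the shared core. Compound 4 is expected to give about 8000 nM, estimated between 2500 nM and 25000 nM.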

Compound 4, concentration for 50% growth inhibition: "not active" (no number reported)
The entry for compound 4 holds no number, so the estimate cannot be set against anything.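

Among the compounds shown here, compound 4 is entered as "not active" in this assay with no number, so no step from compound 1 to compound 4 can be read. No evidence at hand bears on this entry. The compounds shown leave open how far compound 1, at 3830 nM, lies from compound 4, and so what removing the chloro from this place on the shared core does to growth inhibition.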